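The source may hold more compounds than are shown below. What is called first, only, known or untested is meant among the compounds shown, and "the series" means these compounds.

Compound 2 `CCCCCCNC(=O)/N=C(\N)NCCCc1sc(N)nc1C` gives 0.28 in a functional assay on HEK293T cells for agonist activity at histamine H2 receptor (Homo sapiens), read by beta-arrestin recruitment; on this read-out lower numbers stand for smaller maximal responses and higher numbers for larger maximal responses.
Compound 1 `N/C(=N\C(=O)NC1CCCCC1)Nc1cccc(-c2csc(N)n2)c1` shows "not determined" (no result reported) in this assay.

For the measured compounds named here, compound 2 therefore holds the only number at hand, so nothing stands above or below it yet. Compound 3 `Cc1nc(N)sc1CCCN/C(N)=N/C(=O)Nc1ccccc1` differs from compound 2 in one place: phenyl in place of hexyl on an amide-type nitrogen. Going by the values given here, no pair of measured compounds shows what such a swap does here, so the expectation rests on compound 2 alone. The change is expected to give a number 0.020 higher from compound 2 to compound 3 (within the scatter), a small step that could fall either way and may not exceed the usual scatter. Compound 3 is estimated to reach 0.3 in this assay, with a range from 0.12 to 0.55.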

Compound 3, intrinsic activity: the largest response reached, as a fraction of the reference agonist's: 0.25
Beside the measured number, compound 3's estimate is 0.050 above it; the measured number falls inside the stated range.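

In this assay, phenyl in place of hexyl on the amide-type nitrogen gives a number 0.030 lower from compound 2 to compound 3 (within the scatter), so this single swap does not separate the two groups. At this position, a six-membered aromatic ring and an open chain, each of six carbons, leave the maximal response within the usual scatter. No measurement here says why the two groups read alike. Still open, going by these compounds, is whether a longer chain than hexyl, or a benzyl or carboxylic acid group, on this nitrogen would move the response beyond the scatter.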